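Iodo for Fluoro on the Five-Membered Ring

The compounds below may be only part of what the source reports. "The series", "measured", "known", "first", "only" and "open" are said of these compounds alone.

Compound 1 `COc1cccc(C#Cc2csc(F)n2)c1` gives 22.7 nM in an assay on brain for displacement of a labelled ligand from metabotropic glutamate receptor 5 (Rattus norvegicus); on this read-out higher numbers stand for weaker inhibition and lower numbers for stronger inhibition. Among the compounds with values here, compound 2 `N#Cc1cccc(C#Cc2csc(F)n2)c1` gives 1.6 nM in this assay, and the step of a 14-fold lower number from compound 1 to compound 2 (1.15 log units; beyond the scatter) places compound 2 lowest of the two numbers measured so far. Compound 3 `N#Cc1cccc(C#Cc2csc(I)n2)c1` differs from compound 2 by iodo in place of fluoro on an aromatic carbon. Within the data shown here, the only measured step, a 14-fold lower number from compound 1 to compound 2 (1.15 log units; beyond the scatter), concerns an exchange on the other ring and does not bear on swapping one halogen for another, so no step beyond the scatter is expected in this assay. Compound 3 is expected to give 2 nM, with a range from 0.7 nM to 6 nM. That estimate means an expected 1.3-fold higher number from compound 2 to compound 3 (0.10 log units; within the scatter).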

Compound 3, inhibition constant: 4.2 nM
Compound 3: middle estimate off by 2.1-fold (0.32 log units), on the low side, and the stated range covers the measured number.
By their numbers in this assay, from the lowest: compound 2; then compound 3; then compound 1.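

In this assay, within the data shown here, the step of a 2.6-fold higher number from compound 2 to compound 3 (0.42 log units; beyond the scatter) gives the first reading at this position, on the carbon next to the ring nitrogen and the ring sulfur, where the earlier step concerned only the other ring. The number rises beyond the scatter with iodo in place of fluoro, yet the change is modest beside the step of a 14-fold lower number from compound 1 to compound 2 (1.15 log units; beyond the scatter). Nothing available explains the rise. As far as these compounds go, whether chloro, bromo, a methyl group or an amine on this carbon would give a number nearer that of compound 2 stays open. So does whether iodo would have a similar effect with methoxy on the other ring.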